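Removing the last N-methyl from a thiosemicarbazone

The source may hold more compounds than are shown below. What is called first, only, known or untested is meant among the compounds shown, and "the series" means these compounds.

Measured compounds:
compound 1 `CNC(=S)N/N=C/c1nccc2cc(F)ccc12` gives 4080 nM;
compound 2 `CN(C)C(=S)NN=Cc1nccc2ccccc12` gives 29600 nM;
compound 3 `CN(C)C(=S)NN=Cc1nccc2cc(F)ccc12` gives 111 nM.

All three were tested in a functional assay on MIA PaCa-2 cells (Homo sapiens) for cytotoxicity, read by luminescence, with a stated time of 72 h; a higher number here means a weaker inhibitor, a lower number a stronger inhibitor. Compound 1 stands second highest of the three numbers: compound 2 lies one step higher, compound 3 well below it, and in both directions the gap lies beyond the scatter.

Compound 4 `NC(=S)N/N=C/c1nccc2cc(F)ccc12` differs from compound 1 by hydrogen in place of methyl on an amide-type nitrogen. Among the compounds with values here, no measured pair shows this particular change. Within the data shown here, the one single-site step known, a 270-fold lower number from compound 2 to compound 3 (2.43 log units; beyond the scatter), concerns the fluorine on the shared core and says nothing about the thiourea nitrogen. Among the measured compounds shown here, what the values of compound 1 and compound 3 show, with no isolated step between them, is that the dimethyl compound 3 sits far lower than the monomethyl compound 1. Taking away the remaining methyl is therefore expected to move the number upward rather than down, though the size of that move is uncertain.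

Compound 4 is accordingly expected to give 10000 nM, within a range of 3000 nM to 40000 nM, which amounts to an expected step of a 2.5-fold higher number from compound 1 to compound 4 (0.39 log units; beyond the scatter).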

Compound 4, concentration for 90% inhibition: 5440 nM
For compound 4 the middle estimate is 1.8-fold (0.26 log units) above the measured one; low and high end bracket the measured number.
By their numbers in this assay, from the lowest: compound 3; then compounds 1 and 4 (each within the scatter of the next); then compound 2.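

In this assay, within the data shown here, the step from methylamino to amino on the amide-type nitrogen is the first single-site reading at this position: a 1.3-fold higher number from compound 1 to compound 4 (0.12 log units; within the scatter). On the shared fluoro-bearing core, then, the presence or absence of this one methyl leaves the number within the scatter, so the expected upward move does not appear. The printed values place this pair apart from the dimethyl form: compound 1 gives 4080 nM, compound 4 gives 5440 nM, and compound 3, which carries two methyl groups on that nitrogen, gives 111 nM. Nothing available here bears on the reason for this result.

The compounds shown leave open whether an ethyl group or a longer chain on this nitrogen, alongside or in place of a methyl, would give a number like that of compound 3 or like those of compound 1 and compound 4. Among these compounds, they also leave open whether the methyl-to-hydrogen change would stay within the scatter on the core without fluorine, where compound 2 is the only example and carries two methyl groups.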